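From 3-methylphenyl to 4-methylphenyl on a sulfonamide nitrogen

This account rests on a few compounds, and the source may have more. Where it says the series, first, only, none or still open, it means among the compounds named here.

Results so far in a functional assay on MCF7 cells (Homo sapiens) for antiproliferative activity, read by sulforhodamine B assay, with a stated time of 48 h (a higher number here means a weaker inhibitor, a lower number a stronger inhibitor), are these
- compound 1 `CCc1ccccc1NS(=O)(=O)c1ccc(N2CCNC2=O)cc1` gives 350 nM here
- compound 2 `Cc1cccc(NS(=O)(=O)c2ccc(N3CCNC3=O)cc2)c1` gives 190 nM here

On these numbers, compound 2 stands within the scatter of compound 1, and neither can be ranked over the other. Compound 3 `Cc1ccc(NS(=O)(=O)c2ccc(N3CCNC3=O)cc2)cc1` is still unmeasured. It carries 4-methylphenyl in place of 3-methylphenyl on a sulfonamide nitrogen. Among the measured compounds shown here, the only measured step at this nitrogen (a 1.8-fold lower number from compound 1 to compound 2 (0.27 log units; within the scatter)) stayed inside the scatter, so no step beyond the scatter is expected in this assay for this change. The estimated step is small (a 1.2-fold higher number from compound 2 to compound 3 (0.06 log units; within the scatter)). Compound 3 is estimated at 220 nM with a range of 90 nM to 520 nM expected.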

Compound 3, half-maximal inhibitory concentration: 610 nM
Compound 3: middle estimate off by 2.8-fold (0.44 log units), on the low side, and the stated range ends below it.
By their numbers in this assay, from the lowest: compounds 2, 1 and 3 (each within the scatter of the next, the first and the last beyond it).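

Among the compounds shown here, a step of a 3.2-fold higher number from compound 2 to compound 3 (0.51 log units; beyond the scatter) in this assay is the first at this sulfonamide nitrogen to pass the scatter, and it shows that 3-methylphenyl and 4-methylphenyl, though built of the same atoms, are not interchangeable here. The other new step, a 1.7-fold higher number from compound 1 to compound 3 (0.24 log units; within the scatter) stays within the scatter, so compound 1 and compound 3 cannot be ranked. Nothing available explains why the two methylphenyl groups part.

The compounds shown leave open how 2-methylphenyl would compare with these two groups. They also leave open whether a methoxy group or a chlorine atom in place of the methyl would separate in the same way.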